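The source may hold more compounds than are shown below. What is called first, only, known or untested is meant among the compounds shown, and "the series" means these compounds.

Working notes on the series, read in a functional assay on RPMI-8226 cells (Homo sapiens) for antiproliferative activity, read by sulforhodamine B assay, with a stated time of 48 h; on this read-out higher numbers stand for weaker inhibition and lower numbers for stronger inhibition. Compound 1 `O=C(NCCCNc1cc(-c2cn(-c3ccccc3)nc2-c2cccc(O)c2)ccn1)Nc1ccc(F)cc1` gives 870 nM, and compound 2 `O=C(NCCCNc1cc(-c2cn(-c3ccccc3)nc2-c2cccc(O)c2)ccn1)Nc1cccc(C(F)(F)F)c1` gives 730 nM. Going by the values given here, compound 1 therefore stands level with the only other measured compound, and the sole measured step is a 1.2-fold lower number from compound 1 to compound 2 (0.08 log units; within the scatter).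

Compound 3 `COc1cccc(-c2nn(-c3ccccc3)cc2-c2ccnc(NCCCNC(=O)Nc3ccc(F)cc3)c2)c1` has not yet been measured. It departs from compound 1 in one place: methyl in place of hydrogen on an oxygen on an aromatic ring. In words, this is methyl in place of hydrogen on an oxygen on an aromatic ring, or 3-hydroxyphenyl to 3-methoxyphenyl.

The measured step concerns a different place, the group on an amide-type nitrogen, and leaves the 3-hydroxyphenyl untouched. Among the compounds with values here, it therefore bears on this change only loosely, as the one indication of how far a single change has moved the number so far. Within the data shown here, no measured pair yet covers hydroxy to methoxy, so the direction is a tentative call. A small move toward a higher number in this assay is expected, not clearly beyond the scatter, and the range is kept wide. The expected step is a 1.7-fold higher number from compound 1 to compound 3 (0.24 log units; within the scatter). For compound 3 the estimated value is 1500 nM, with an expected range of 500 nM to 4500 nM.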

Compound 3, half-maximal inhibitory concentration: 5960 nM
Compound 3: the middle estimate sits 4.0-fold (0.60 log units) below what was measured; the whole stated range lies below it.
By their numbers in this assay, from the lowest: compounds 2 and 1 (each within the scatter of the next); then compound 3.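

Methyl in place of hydrogen on an oxygen on an aromatic ring, hydroxy to methoxy, brings a 6.9-fold higher number from compound 1 to compound 3 (0.84 log units; beyond the scatter) in this assay, so this place in the series answers to a single added methyl, whereas the one earlier step, on the group on an amide-type nitrogen, a 1.2-fold lower number from compound 1 to compound 2 (0.08 log units; within the scatter), stayed within the scatter. Going by these compounds alone, this is the first change that lies beyond the scatter, and within this pair the 3-hydroxyphenyl goes with the lower number, though the reading rests on one pair carrying the 4-fluorophenyl group. Nothing measured on these compounds accounts for the size of the step.

The compounds shown leave open whether hydroxy to methoxy moves the number as far when the 3-(trifluoromethyl)phenyl group of compound 2 stands on the amide-type nitrogen, and whether the step follows the loss of the hydrogen or the gain of the methyl. An amine or a fluorine in place of the hydroxy, or an ethoxy in place of the methoxy, would bear on that second question.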